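A few compounds are considered here, and "the series" means these few. Any claim that something is new, unique, unknown or untested is made for them only; others in the source may bear on it.

Measured in a functional assay on NCI-H1581 cells (Homo sapiens) for antiproliferative activity, read by CCK-8 assay, with a stated time of 72 h; on this read-out lower numbers stand for stronger inhibition and higher numbers for weaker inhibition:
- Compound 1 `COc1cc(OC)c(Cl)c(-c2ccc3c(NC(=O)c4ccc(N5CCN(C)CC5)cc4)n[nH]c3n2)c1Cl`: 1.7 nM
- Compound 2 `COc1cc(OC)c(Cl)c(-c2ccc3c(NC(=O)c4ccc(N5CCCCC5)cc4)n[nH]c3n2)c1Cl`: 558 nM
- Compound 3 `C=CCN1CCN(c2ccc(C(=O)Nc3n[nH]c4nc(-c5c(Cl)c(OC)cc(OC)c5Cl)ccc34)cc2)CC1`: 3.3 nM

Compound 3 stands near compound 1 and far from compound 2. The numbers show a 1.9-fold higher number from compound 1 to compound 3 (0.29 log units; within the scatter), and also a 170-fold lower number from compound 2 to compound 3 (2.23 log units; beyond the scatter).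

The next compound, compound 4 `COc1cc(OC)c(Cl)c(-c2ccc3c(NC(=O)c4ccc(N5CCN(S(C)(=O)=O)CC5)cc4)n[nH]c3n2)c1Cl`, has methylsulfonyl in place of allyl on an amine nitrogen in a ring.

Among the compounds with values here, two measured steps bear on this change. A change of the group on this same ring nitrogen gave only a 1.9-fold higher number from compound 1 to compound 3 (0.29 log units; within the scatter). Putting piperidin-1-yl in place of 4-methylpiperazin-1-yl gave a 330-fold higher number from compound 1 to compound 2 (2.52 log units; beyond the scatter), so that swap of the whole ring group mattered far more. Within the data shown here, no measured compound carries methylsulfonyl on this nitrogen, so neither step can be carried over directly, and the first is the smaller guide to a group this different from allyl. The ring nitrogen stays in place, which argues against a change as large as the second step. A moderate rise, beyond the scatter, therefore seems most likely.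

The estimated step is a 12-fold higher number from compound 3 to compound 4 (1.08 log units; beyond the scatter). Compound 4 is expected at 40 nM, with an estimated range of 6 nM to 300 nM.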

Compound 4, half-maximal inhibitory concentration: 245 nM
The estimate for compound 4 lay 6.1-fold (0.79 log units) below the measured number, and the stated range covers the measured number.
By their numbers in this assay, from the lowest: compounds 1 and 3 (each within the scatter of the next); then compound 4; then compound 2.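

The group on this ring nitrogen is not a free choice: methyl and allyl sit within the scatter of each other, but methylsulfonyl gives a 74-fold higher number from compound 3 to compound 4 (1.87 log units; beyond the scatter) and, measured against the methyl group, a 140-fold higher number from compound 1 to compound 4 (2.16 log units; beyond the scatter) on the same scaffold. Keeping the second ring nitrogen is therefore not enough on its own to hold the low numbers seen with methyl and allyl. Measured against piperidin-1-yl, 4-(methylsulfonyl)piperazin-1-yl keeps only a modest advantage, with a 2.3-fold lower number from compound 2 to compound 4 (0.36 log units; beyond the scatter) as the step, so the substituent on this nitrogen can cancel most of the large gain seen when compound 2 is compared with compound 1 or compound 3.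

No measurement available here explains why methylsulfonyl differs so sharply from methyl and allyl.

The compounds shown leave open how a plain hydrogen, an acetyl group or a 2-hydroxyethyl chain on this nitrogen would compare, and so whether the loss is particular to methylsulfonyl or extends to other groups joined through a sulfur or a carbonyl.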